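From (2-Phenylethenyl)carbonyl to (4-Cyanophenyl)sulfonyl: Expecting Compound 4

The source may hold more compounds than are shown below. What is called first, only, known or untested is meant among the compounds shown, and "the series" means these compounds.

Three compounds have been measured in a functional assay on MCF7 cells (Homo sapiens) for cytotoxicity, read by MTT assay, with a stated time of 48 h; on this read-out higher numbers stand for weaker inhibition and lower numbers for stronger inhibition:
- Compound 1 `CCN(CC)c1ccc2cc(C(=O)c3ccc(N4CCN(C(=O)CN5CCN(C(=O)CCl)CC5)CC4)cc3)oc2c1` gives > 40000 nM, which is a limit of the assay rather than a number.
- Compound 2 `CCN(CC)c1ccc2cc(C(=O)c3ccc(N4CCN(C(=O)CN5CCN(C(=O)/C=C/c6ccccc6)CC5)CC4)cc3)oc2c1` gives 13400 nM.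
- Compound 3 `CCN(CC)c1ccc2cc(C(=O)c3ccc(N4CCN(C(=O)CN5CCN(S(=O)(=O)C6CC6)CC5)CC4)cc3)oc2c1` gives > 40000 nM, again a limit of the assay.

For the measured compounds named here, compound 2 thus stands alone: it is the only compound with an actual number, while the other two sit at the limit of > 40000 nM in this assay, at which 2 of the 3 values shown sit. The unmeasured compound 4 `CCN(CC)c1ccc2cc(C(=O)c3ccc(N4CCN(C(=O)CN5CCN(S(=O)(=O)c6ccc(C#N)cc6)CC5)CC4)cc3)oc2c1` differs from compound 2 in one place: (4-cyanophenyl)sulfonyl in place of (2-phenylethenyl)carbonyl on an amine nitrogen in a ring.

Going by the values given here, two measured steps bear on this change. The step of an at least 2.9-fold lower number from compound 1 to compound 2 (0.47 log units; beyond the scatter) shows that the (2-phenylethenyl)carbonyl group is what brought the number down from the limit. The step of an at least 2.9-fold higher number from compound 2 to compound 3 (0.47 log units; beyond the scatter) shows that putting a sulfonyl group on the same ring nitrogen in place of that group sent the number back up to the limit. Compound 4 carries a sulfonyl group at the same position, so the expectation is a rise of a 3.4-fold higher number from compound 2 to compound 4 (0.53 log units; beyond the scatter) in this assay. Compound 4 is therefore estimated at 45000 nM, in the range 15000 nM to 150000 nM, with a real chance that only a limit is reported.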

Compound 4, half-maximal inhibitory concentration: > 40000 nM
Compound 4 gave a limit, no number; the forecaster's own chance of this, stated with the estimate: 65%; the middle value is on the limit's open side.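

The entering (4-cyanophenyl)sulfonyl group carries the same kind of six-membered aromatic ring of carbon only as the (2-phenylethenyl)carbonyl group it replaces, yet the change still gives an at least 2.9-fold higher number from compound 2 to compound 4 (0.47 log units; beyond the scatter) in this assay. An aromatic ring on this group is therefore not enough to keep a measurable number, something compound 3, with its cyclopropyl, could not show. Among the compounds shown, only the (2-phenylethenyl)carbonyl group gives a number, and compound 4 joins the others at a limit of the assay rather than a number: the limit of > 40000 nM in this assay, at which 3 of the 4 values shown sit.

With limits at both ends, the steps from compound 1 and compound 3 to compound 4 cannot be read, so any difference among these three stays hidden. As far as these compounds go, it also remains open whether a benzoyl group or a (2-phenylethyl)carbonyl group on the same ring nitrogen would give a number, which would separate the part played by the carbonyl from that of the double bond.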